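A Methyl on the Ring Nitrogen: Expected Cytotoxicity

This account rests on a few compounds, and the source may have more. Where it says the series, first, only, none or still open, it means among the compounds named here.

Compound 1 `C=C1CN/C(=N/c2ccccc2)S1` was tested in an ADME assay on TERT-RPE1 cells (Homo sapiens) for cytotoxicity, read by MTT assay, with a stated time of 72 h; on this read-out higher numbers stand for weaker inhibition and lower numbers for stronger inhibition. In this assay compound 1 gives > 100000 nM, which is a limit of the assay rather than a number. A second compound, compound 2 `COc1ccc(/C=C2\S/C(=N\c3ccc(OC)cc3)N(C)C2=O)cc1`, was run alongside it. In this assay compound 2 gives > 100000 nM, again a limit and not a number. Among the measured compounds shown here, all that the numbers show is the limit of > 100000 nM in this assay, at which 2 of the 2 values shown sit, so compound 1 stands level with the only other value at hand, and no step between measured compounds can be drawn. Compound 3 `C=C1CN(C)/C(=N/c2ccccc2)S1` has not yet been tested. It differs from compound 1 by methyl in place of hydrogen on an amine nitrogen in a ring. For the measured compounds named here, no measured step involves a change of this kind, so the expected step from compound 1 to compound 3 is none beyond the scatter, and another limit is the most likely outcome. The estimate for compound 3 is 100000 nM, within a range from 50000 nM to 300000 nM. The step of a number no higher from compound 1 to compound 3 (the limit leaves the size open) is what this estimate means.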

Compound 3, half-maximal inhibitory concentration: > 100000 nM
Compound 3 was reported as a limit (the forecaster's own chance of this, stated with the estimate: 85%); the middle value sits exactly at the limit.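

No step can be read from compound 1 to compound 3 in this assay, because both results are limits and not numbers: the limit of > 100000 nM in this assay, at which 3 of the 3 values shown sit.

The compounds shown leave open whether methyl in place of hydrogen on an amine nitrogen in a ring alters cytotoxicity at all, and what true value lies behind each limit.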